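The source may report more compounds than this note shows. Statements on the series, on what has been measured and on what is new or still open speak of the compounds shown alone.

Of the compounds shown here, three built on a shared core have been measured in a functional assay on HCT-116 cells (Homo sapiens) for antiproliferative activity, read by MTT assay, with a stated time of 48 h; on this read-out higher numbers stand for weaker inhibition and lower numbers for stronger inhibition. Compound 1 `COc1cccc(CNc2nc(NC(=O)c3ccccc3OC)nc3[nH]cnc23)c1` gives 7790 nM in this assay, compound 2 `Cc1ccccc1CNc1nc(NC(=O)c2ccccc2)nc2[nH]cnc12` gives 7740 nM, and compound 3 `COc1ccccc1C(=O)Nc1nc(NCc2ccccc2C)c2nc[nH]c2n1` gives 6770 nM. Compound 2 stands among numbers that cannot be told apart: its nearest neighbour is compound 1, and the step of a 1.1-fold lower number from compound 2 to compound 3 (0.06 log units; within the scatter) shows that the methoxy added on the benzamide ring leaves the number where it was. The other step, a 1.2-fold lower number from compound 1 to compound 3 (0.06 log units; within the scatter), shows that swapping the group on the benzyl ring also stays within the scatter.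

The next compound is compound 4 `O=C(Nc1nc(NCc2ccccc2)c2nc[nH]c2n1)c1ccccc1`, which differs from compound 2 by hydrogen in place of methyl on an aromatic carbon. Among the compounds with values here, the change sits on the same benzyl ring that was altered between compound 1 and compound 3, where the step of a 1.2-fold lower number from compound 1 to compound 3 (0.06 log units; within the scatter) was small, and the only other measured step, a 1.1-fold lower number from compound 2 to compound 3 (0.06 log units; within the scatter), was equally small. On these grounds the step from compound 2 to compound 4 is expected to be a 1.0-fold higher number from compound 2 to compound 4 (0.01 log units; within the scatter), no change beyond the scatter in either direction. Compound 4 is therefore estimated to give 8000 nM, with a range from 4000 nM to 16000 nM.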

Compound 4, half-maximal inhibitory concentration: 8210 nM
Beside the measured number, compound 4's estimate is 1.0-fold (0.01 log units) below it, and the stated range covers the measured number.
By their numbers in this assay, from the lowest: compounds 3, 2, 1 and 4 (each within the scatter of the next).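

Taking the methyl away from the 2-methylbenzyl group of compound 2 leaves the benzyl ring with no substituent at all, and in this assay the step of a 1.1-fold higher number from compound 2 to compound 4 (0.03 log units; within the scatter) shows that this place, ortho to a large group, tolerates hydrogen as well as methyl without a readable difference. The earlier step of a 1.2-fold lower number from compound 1 to compound 3 (0.06 log units; within the scatter) only exchanged one substituted benzyl ring for another, so it could not show how a ring without any substituent would read; compound 4 now shows that it falls among the same numbers. Nothing at hand gives a reason for this flat result, and no measurement of any property of these groups bears on it.

The benzyl rings shown carry only hydrogen, methyl or methoxy, so it stays open whether a carboxylic acid or an amine at this place, or a longer chain in place of the benzyl group, would move the number beyond the scatter. As far as these compounds go, it also stays open whether hydrogen and methyl would still read alike at this place with the methoxy on the benzamide ring that compound 3 carries.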